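Methyl-capped indole rejoins the trimethoxyphenyl series

The source may hold more compounds than are shown below. What is called first, only, known or untested is meant among the compounds shown, and "the series" means these compounds.

Compound 3 `COc1cc(-c2ccnc3cc(-c4ccc(C(C)=O)cc4)nn23)cc(OC)c1OC` gives 4100 nM in a functional assay on A549 cells (Homo sapiens) for inhibition, read by CCK-8 assay, with a stated time of 48 h (a higher number here means a weaker inhibitor, a lower number a stronger inhibitor), the higher of the two numbers seen so far; compound 1 `COc1cc(-c2ccnc3cc(-c4ccc5cc[nH]c5c4)nn23)cc(OC)c1OC` gives 170 nM. Compound 2 `COc1cc(-c2ccnc3cc(-c4ccc(C(C)(C)C)cc4)nn23)cc(OC)c1OC` reaches only the assay limit of > 10000 nM. The change to compound 4 `COc1cc(-c2ccnc3cc(-c4ccc5ccn(C)c5c4)nn23)cc(OC)c1OC` is 1-methyl-1H-indol-6-yl in place of 4-acetylphenyl on an aromatic carbon. It largely reverses a 24-fold higher number from compound 1 to compound 3 (1.38 log units; beyond the scatter), and the step of an at least 2.4-fold lower number from compound 2 to compound 3 (0.38 log units; beyond the scatter) points the same way, while the large at least 58-fold higher number from compound 1 to compound 2 (1.76 log units; beyond the scatter) shows how far the indole-free compounds sit from compound 1. Compound 4 differs from compound 1 only by the methyl of the 1-methyl-1H-indol-6-yl group, so a large fall toward compound 1 is expected, a 12-fold lower number from compound 3 to compound 4 (1.07 log units; beyond the scatter), though perhaps not the whole way. Compound 4 is therefore estimated at 350 nM, between 100 nM and 1500 nM.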

Compound 4, half-maximal inhibitory concentration: 829 nM
Compound 4: middle estimate off by 2.4-fold (0.37 log units), on the low side; low and high end bracket the measured number.
By their numbers in this assay, from the lowest: compound 1; then compound 4; then compound 3. At a limit, above all of these: compound 2.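

In this assay, methyl in place of hydrogen on the aromatic nitrogen of the indole costs activity, a 4.9-fold higher number from compound 1 to compound 4 (0.69 log units; beyond the scatter). Yet the 1-methyl-1H-indol-6-yl group, with no hydrogen-bond donor, still improves on 4-acetylphenyl at this position, a 4.9-fold lower number from compound 3 to compound 4 (0.69 log units; beyond the scatter), so the indole's advantage does not rest on that hydrogen alone. The gain over 4-(tert-butyl)phenyl is larger, an at least 12-fold lower number from compound 2 to compound 4 (1.08 log units; beyond the scatter), though that step rests on a limit: the limit of > 10000 nM in this assay, at which 1 of the 4 values shown sits.

Going by these compounds, whether an ethyl group or a longer chain ending in an amine on that nitrogen would cost more remains open.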